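Compound 3 to compound 4: methoxy in place of chloro

The source may report more compounds than this note shows. Statements on the series, on what has been measured and on what is new or still open speak of the compounds shown alone.

Compound 1 `O=C(NO)c1cnc(N2C[C@H]3CN(C(=O)CCCOc4ccccc4)C[C@H]3C2)nc1`: 900 nM
Compound 2 `O=C(NO)c1cnc(N2C[C@H]3CN(Cc4cc(Cl)cc(Cl)c4)C[C@H]3C2)nc1`: 300 nM
Compound 3 `O=C(NO)c1cnc(N2C[C@H]3CN(Cc4ccc(Cl)cc4)C[C@H]3C2)nc1`: 230 nM

In a functional assay on U-937 cells (Homo sapiens) for inhibition, read by sulforhodamine B assay, with a stated time of 72 h (a higher number here means a weaker inhibitor of growth, a lower number a stronger inhibitor of growth), compound 3 gives 230 nM, within the scatter of compound 2. Compound 1 gives 900 nM, a higher number than that of compound 3 and beyond the scatter. Compound 4 `COc1ccc(CN2C[C@@H]3CN(c4ncc(C(=O)NO)cn4)C[C@@H]3C2)cc1`, not yet measured, carries methoxy in place of chloro on an aromatic carbon, para to a large group (methoxy in place of chloro on an aromatic carbon). Within the data shown here, only one measured step bears on this aromatic ring: a 1.3-fold lower number from compound 2 to compound 3 (0.12 log units; within the scatter). Among the measured compounds shown here, no measured compound carries methoxy, so that step is only indirect evidence. No change beyond the scatter is therefore expected. The estimated change is a 1.2-fold higher number from compound 3 to compound 4 (0.09 log units; within the scatter). For compound 4 the estimated value is 280 nM, expected to fall between 100 nM and 700 nM.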

Compound 4, concentration for 50% growth inhibition: 550 nM
Compound 4: the middle estimate sits 2.0-fold (0.29 log units) below what was measured, and the stated range covers the measured number.
By their numbers in this assay, from the lowest: compounds 3, 2, 4 and 1 (each within the scatter of the next, the first and the last beyond it).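

In this assay, among these compounds, methoxy in place of chloro on this aromatic carbon gives the first step on this ring that lies beyond the scatter (a 2.4-fold higher number from compound 3 to compound 4 (0.38 log units; beyond the scatter)). Compared with the 3,5-dichlorophenyl group, however, the 4-methoxyphenyl group remains within the scatter (a 1.8-fold higher number from compound 2 to compound 4 (0.26 log units; within the scatter)), so only the pair differing at this one carbon is separated. Nothing available explains the step.

Going by these compounds, whether fluoro, hydroxyl or an amine on this carbon would give a number nearer that of chloro or of methoxy remains open. So does whether ethoxy would follow methoxy.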